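Two limits and an isopropyl swap

The compounds below may be only part of what the source reports. "The series", "measured", "known", "first", "only" and "open" are said of these compounds alone.

- compound 1 `O=C(O)c1ccc(-c2nn(Cc3ccccc3)c3ccccc23)cc1` gives > 10000 nM
- compound 2 `CCCNC(=O)c1ccc(-c2nn(Cc3ccccc3)c3ccccc23)cc1` gives > 10000 nM

In a functional assay on cells (Platelet, Homo sapiens) for inhibition (a lower number here means a stronger inhibitor, a higher number a weaker inhibitor), compound 2 stands at > 10000 nM, which is a limit and not a number. Compound 1 also gives a limit, > 10000 nM. The evidence so far is the limit of > 10000 nM in this assay, at which 2 of the 2 values shown sit. Compound 3 `CC(C)NC(=O)c1ccc(-c2nn(Cc3ccccc3)c3ccccc23)cc1` differs from compound 2 by isopropyl in place of propyl on an amide-type nitrogen. Going by the values given here, the one measured step, a step that the two limits leave unreadable from compound 1 to compound 2, has no readable size, so it offers no guide to how large this change might be. No step beyond the scatter is therefore expected, and a further limit is the likeliest result. The estimated step is a number no higher from compound 2 to compound 3 (the limit leaves the size open). For compound 3 the expected value is 10000 nM, within an estimated range of 4000 nM to 20000 nM.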

Compound 3, half-maximal inhibitory concentration: > 10000 nM
Compound 3 ended at the assay's limit (the forecaster's own chance of this, stated with the estimate: 80%); the middle value lies on the limit itself.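

Going by these compounds alone, compound 1, compound 2 and compound 3 all sit at a limit in this assay, so no step among them can be read. On these data alone, how strongly each inhibits, and whether propyl and isopropyl differ at all, stays open.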